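Aryl exchange on the alkyne: from compound 2 to compound 3

The source may hold more compounds than are shown below. What is called first, only, known or untested is meant among the compounds shown, and "the series" means these compounds.

Two compounds of this series have been run in an assay on CHO cells for displacement of a labelled ligand from adenosine receptor A1 (Homo sapiens), read by scintillation counting, with a stated time of 60 min, tested at 10 uM; a higher number here means more inhibition at the concentration tested (going by the name of the read-out), a lower number less inhibition. Compound 1 `CNC(=O)[C@@]12C[C@@H]1[C@@H](n1cnc3c(NC)nc(C#Cc4ccc(Cl)cc4)nc31)[C@H](O)[C@@H]2O` gives 13%, and compound 2 `CNC(=O)[C@@]12C[C@@H]1[C@@H](n1cnc3c(NC)nc(C#Cc4cccnn4)nc31)[C@H](O)[C@@H]2O` gives 11%. Compound 2 carries the lower of the two numbers, but the gap to compound 1 is within the scatter: a number 2 percentage points lower from compound 1 to compound 2 (within the scatter). Compound 3 `CNC(=O)[C@@]12C[C@@H]1[C@@H](n1cnc3c(NC)nc(C#Cc4ccsc4)nc31)[C@H](O)[C@@H]2O` awaits measurement in this assay. Its difference from compound 2 is thiophen-3-yl in place of pyridazin-3-yl on a triple-bonded carbon. For the measured compounds named here, the only measured step that bears on this one is the exchange of the aryl group on the triple-bonded carbon between compound 1 and compound 2, and that step stayed within the scatter. A second exchange at the same place is therefore expected to give no step beyond the scatter, so that a number 1 percentage points higher from compound 2 to compound 3 (within the scatter) is the estimated change. For compound 3 the expected read-out is 12%, between 2% and 25%.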

Compound 3, a percentage reported as inhibition, at one concentration (the size of the read-out at that concentration, not a potency): 11%
Estimate against measurement, compound 3: 1 percentage points above; low and high end bracket the measured number.
By their numbers in this assay, from the lowest: compounds 2, 3 and 1 (each within the scatter of the next).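

In this assay the exchange on the triple-bonded carbon now reaches a five-membered aromatic ring holding a sulfur atom, and the read-out stays flat: the two new steps are no change at the digits printed from compound 2 to compound 3 (within the scatter) and a number 2 percentage points lower from compound 1 to compound 3 (within the scatter). Across 4-chlorophenyl, pyridazin-3-yl and thiophen-3-yl, neither ring size nor the hetero atoms in the ring separate any of the three compounds beyond the scatter at this place. No supporting data are available that would account for this flat result.

From the compounds shown here alone, all three compounds carry an aromatic ring here, so it remains open whether an aliphatic amine, a carboxylic acid or a longer alkyl chain on the triple-bonded carbon would shift the read-out in this assay at all. Also open, going by these compounds, is whether changes elsewhere on the shared core would do so.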